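Compound 4: the S form at the stereocentre

The compounds below may be only part of what the source reports. "The series", "measured", "known", "first", "only" and "open" are said of these compounds alone.

In a functional assay on HOS-TE85 cells (Homo sapiens) for inhibition, read by CCK-8 assay, with a stated time of 72 h (a lower number here means a stronger inhibitor, a higher number a weaker inhibitor), compound 2 `Cc1ccnc(N2C(=O)CSC2c2cccc(C(=O)NCCCCn3cccn3)c2)c1` gives 19.6 nM. Compound 1 `Cc1ccnc(N2C(=O)CS[C@@H]2c2cccc(C(=O)NCCCCn3cccn3)c2)c1` gives 21.9 nM, and compound 3 `O=C(NCCCCn1cccn1)c1cccc(C2SCC(=O)N2c2cc(Cl)ccn2)c1` gives 36.4 nM. The three values lie within the scatter of one another, so compound 2 does not separate from either neighbour.

The next structure is compound 4 `Cc1ccnc(N2C(=O)CS[C@H]2c2cccc(C(=O)NCCCCn3cccn3)c2)c1`. The change is the two compounds have the same atoms and bonds; at least one stereo element is drawn with a configuration in one of them and without one in the other: 1 of 1 stereo elements differ; a stereocentre at a saturated ring carbon is drawn without a configuration in compound 2 and S in compound 4. The atoms and bonds stay the same, and a stereocentre at a saturated ring carbon is drawn S.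

Among the measured compounds shown here, the closest precedent is a 1.1-fold lower number from compound 1 to compound 2 (0.05 log units; within the scatter), where the sole structural difference is the fact that one of compounds 1 and 2 is drawn with a defined configuration and the other without, at the place where they differ. That step lies within the scatter, and it concerns the same stereocentre, drawn R in compound 1. The other measured step, a 1.9-fold higher number from compound 2 to compound 3 (0.27 log units; within the scatter), has chloro in place of methyl on an aromatic carbon and leaves the stereocentre as it is, so it has little bearing here.

No step beyond the scatter is therefore expected in this assay, and no direction is favoured. The estimated step is a 1.0-fold higher number from compound 2 to compound 4 (0.01 log units; within the scatter). One measured pair cannot exclude a weaker S form, so the range extends further upward. For compound 4, the expected value is 20 nM, with an estimated range of 9 nM to 50 nM.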

Compound 4, half-maximal inhibitory concentration: > 10000 nM
Compound 4 was reported as a limit; the forecaster's own chance of this, stated with the estimate: 3%; middle value at least 500-fold (2.69 log units) from the limit.
By their numbers in this assay, from the lowest: compounds 2, 1 and 3 (each within the scatter of the next). At a limit, above all of these: compound 4.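

In this assay compound 4 gives > 10000 nM, a limit of the assay and not a number. This stereocentre is now the most sensitive place measured in the series, with an at least 450-fold higher number from compound 1 to compound 4 (2.65 log units; beyond the scatter) for the change from the R to the S drawing and an at least 510-fold higher number from compound 2 to compound 4 (2.70 log units; beyond the scatter) against the compound drawn without a configuration. The earlier step at this stereocentre, a 1.1-fold lower number from compound 1 to compound 2 (0.05 log units; within the scatter), lay within the scatter and gave no sign of this, whereas the new pair places the measured activity with the R form and not the S form, with configuration as the only thing separating the two: the fact that compounds 1 and 4 differ only in the configuration as drawn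

The stereochemical composition of compound 2 is not given by its drawing, so the data do not show how much of each form it contains. From the compounds shown here alone, it also remains open whether the same gap between the R and S forms appears with chloro in place of methyl, or with an amine, a carboxylic acid or a longer chain in the amide side chain of compound 1.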